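A few compounds are considered here, and "the series" means these few. Any claim that something is new, unique, unknown or untested is made for them only; others in the source may bear on it.

In an assay on HEK293 cells for displacement of a labelled ligand from NPC1-like intracellular cholesterol transporter 1 (Homo sapiens) (a lower number here means a stronger inhibitor, a higher number a weaker inhibitor), compound 3 `CC(C)(C)c1ccc(C(=O)N2CCC3(CC2)C(=O)N(CC(=O)NCCCN)CN3c2ccccc2)cc1` gives 4200 nM, the lowest of the three numbers at hand. Compound 2 `CC(C)(C)OC(=O)NCCCCNC(=O)CN1CN(c2ccccc2)C2(CCN(C(=O)c3ccc(C4CCCCC4)cc3)CC2)C1=O` gives 4600 nM, which lies within the scatter of compound 3, while compound 1 `CC(C)(C)OC(=O)NCCCCCNC(=O)CN1CN(c2ccccc2)C2(CCN(C(=O)c3ccc(C(C)(C)C)cc3)CC2)C1=O` gives 13700 nM. Within the data shown here, the only step between compounds differing in one place is a 3.3-fold lower number from compound 1 to compound 3 (0.51 log units; beyond the scatter), and it alters the same amide side chain that is altered again here. Compound 4 `CC(C)(C)c1ccc(C(=O)N2CCC3(CC2)C(=O)N(CC(=O)N2CCCC(CO)C2)CN3c2ccccc2)cc1` differs from compound 3 by 3-(hydroxymethyl)piperidin-1-yl in place of (3-aminopropyl)amino on a carbonyl carbon. Among the measured compounds shown here, no measured pair shows this exchange, and the one step on this chain was modest, so the expected step is a 1.1-fold higher number from compound 3 to compound 4 (0.03 log units; within the scatter), within the scatter. Compound 4 is therefore estimated at 4500 nM, with a range from 1500 nM to 14000 nM.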

Compound 4, half-maximal inhibitory concentration: 8200 nM
The estimate for compound 4 lay 1.8-fold (0.26 log units) below the measured number; measured number inside the range.
By their numbers in this assay, from the lowest: compounds 3, 2, 4 and 1 (each within the scatter of the next, the first and the last beyond it).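

Among these compounds, on the carbonyl carbon of the amide side chain, a ring takes the place of an open chain for the first time, giving a 2.0-fold higher number from compound 3 to compound 4 (0.29 log units; within the scatter). The shared core with the 4-tert-butylbenzoyl group therefore holds its reading in this assay without the (3-aminopropyl)amino group and its free amine, and with 3-(hydroxymethyl)piperidin-1-yl in its place. Nothing available explains this result. The compounds shown leave open whether plain piperidin-1-yl or 3-(aminomethyl)piperidin-1-yl on this carbonyl carbon would read alike. They also leave open what a carboxylic acid at the end of the chain would give.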